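The source may hold more compounds than are shown below. What is called first, only, known or untested is meant among the compounds shown, and "the series" means these compounds.

Compound 1 `O=C(Nc1cccc(-n2cc(-c3ccncc3)c(-c3cc(O)cc(Cl)c3)n2)c1)Nc1ccc(Cl)c(C(F)(F)F)c1` gives 1.88% in a functional assay on OVCAR-3 cells (Homo sapiens) for inhibition, read by sulforhodamine B assay, with a stated time of 48 h, tested at 10 uM; on this read-out lower numbers stand for a stronger effect and higher numbers for a weaker effect at the one concentration tested.
Compound 2 `O=C(Nc1cccc(-n2cc(-c3ccncc3)c(-c3cc(O)cc(Cl)c3)n2)c1)Nc1ccc(Cl)c(Cl)c1` gives -47.4% in this assay.
Compound 3 `COc1cc(Cl)cc(-c2nn(-c3cccc(NC(=O)Nc4cc(C(F)(F)F)cc(C(F)(F)F)c4)c3)cc2-c2ccncc2)c1` gives -1.62% in this assay.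

Among these three, compound 2 stands at the lowest number in this assay, with compound 1 and compound 3 both beyond the scatter above it. Going by the values given here, the one measured step, a number 49.3 percentage points lower from compound 1 to compound 2 (beyond the scatter), concerns the aryl urea and not the part changed here. Compound 4 `COc1cc(Cl)cc(-c2nn(-c3cccc(NC(=O)Nc4ccc(Cl)c(Cl)c4)c3)cc2-c2ccncc2)c1` differs from compound 2 by methyl in place of hydrogen on an oxygen on an aromatic ring. Among the compounds with values here, no measured step bears directly on this change; compound 3, which carries methoxy, and compound 1, which carries hydroxy, also differ in the urea, and their values stand close together. With nothing direct to go on, the expected step of a number 17.4 percentage points higher from compound 2 to compound 4 (beyond the scatter) is a modest move toward a higher number, possibly none beyond the scatter. Compound 4 is estimated at -30%, within -60% to 2%.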

Compound 4, a percentage reported as activity, at one concentration (the size of the read-out at that concentration, not a potency): 4.11%
Beside the measured number, compound 4's estimate is 34.1 percentage points below it; the whole stated range lies below it.
By their numbers in this assay, from the lowest: compound 2; then compounds 3, 1 and 4 (each within the scatter of the next).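

In this assay, the change from 3-chloro-5-hydroxyphenyl to 3-chloro-5-methoxyphenyl is a number 51.5 percentage points higher from compound 2 to compound 4 (beyond the scatter), a large step. Going by these compounds alone, it gives the first direct comparison at this position and shows that, with the urea of compound 2, a methyl on this oxygen is enough to remove the low number. Nothing available explains this step.

From the compounds shown here alone, whether hydroxy to methoxy has the same effect with other aryl ureas remains open. So does whether an amine or a longer chain in this place would retain the low number of compound 2.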